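This account rests on a few compounds, and the source may have more. Where it says the series, first, only, none or still open, it means among the compounds named here.

Compounds measured so far, each in a functional assay on DU-145 cells (Homo sapiens) for inhibition, read by MTT assay, with a stated time of 24 h; on this read-out lower numbers stand for stronger inhibition and higher numbers for weaker inhibition:

Compound 1, `CCOC(=O)C1=Cc2ccccc2OC1(OCc1cc(-c2ccc(OC)cc2)no1)C(F)(F)F`. In this assay compound 1 sits at a limit of the assay, > 150000 nM.
Compound 2, `CCOC(=O)C1=Cc2ccccc2OC1(OCc1cn(CC(=O)Nc2ccccc2Br)nn1)C(F)(F)F`. In this assay compound 2 likewise sits at a limit, > 150000 nM.
Compound 3, `CCOC(=O)C1=Cc2ccccc2OC1(OCc1cc(-c2ccc(C)cc2)no1)C(F)(F)F`. In this assay compound 3 also sits at a limit, > 150000 nM.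

Compound 2 thus stands where every measured member of the series stands: at the limit of > 150000 nM in this assay, at which 3 of the 3 values shown sit. No number has been read for it, only the limit.

Compound 4, `CCOC(=O)C1=Cc2ccccc2OC1(OCc1cn(-c2cccc(C(F)(F)F)c2)nn1)C(F)(F)F`, is not yet measured. It differs from compound 2 as follows. 3-(trifluoromethyl)phenyl in place of ((2-bromophenyl)carbamoyl)methyl on an aromatic nitrogen

Among the compounds with values here, the only step between measured compounds that differ in one place is a step that the two limits leave unreadable from compound 1 to compound 3, and its size cannot be read, since both ends are limits. It also concerns a different ring from the one changed here. Within the data shown here, no measured step therefore bears on the change from compound 2 to compound 4 in a readable way, and no step beyond the scatter can be expected in this assay in either direction; the expectation is simply that compound 4 remains near the limit.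

The estimate for compound 4 is 200000 nM, with a range from 100000 nM to 500000 nM. The step this estimate means is a step that the limit leaves unreadable from compound 2 to compound 4, and it is expected to sit within the scatter, most likely reported again as a limit rather than a number.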

Compound 4, half-maximal inhibitory concentration: > 150000 nM
Compound 4 ended at the assay's limit; the forecaster's own chance of this, stated with the estimate: 85%; the middle value does not contradict the limit.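

The step from compound 2 to compound 4 cannot be read, as both ends are limits of the assay. The compounds shown leave open whether any change to this series gives a readable value in this assay, since all sit at one limit: the limit of > 150000 nM in this assay, at which 4 of the 4 values shown sit.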